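Moving a Methyl on the Aryl Tail: Compound 4

The source may report more compounds than this note shows. Statements on the series, on what has been measured and on what is new or still open speak of the compounds shown alone.

Measured compounds:
compound 1 `O=C(CCC1=CCN(CCCc2ccc(Cl)cc2)C1=O)NO` gives 3330 nM in a functional assay on ACHN cells (Homo sapiens) for inhibition, read by sulforhodamine B assay; a higher number here means a weaker inhibitor of growth, a lower number a stronger inhibitor of growth
compound 2 `CCOc1ccc(CCCN2CC=C(CCC(=O)NO)C2=O)cc1` gives 3330 nM in this assay
compound 3 `Cc1ccccc1CCCN1CC=C(CCC(=O)NO)C1=O` gives 3330 nM in this assay

Compound 3 stands level with compounds 1 and 2 in this assay; none of the three is separated from another beyond the scatter. The change to compound 4 `Cc1ccc(CCCN2CC=C(CCC(=O)NO)C2=O)cc1` is 4-methylphenyl in place of 2-methylphenyl on a saturated chain carbon, three bonds along the chain from an amide-type nitrogen in a ring. Two measured steps alter the same aryl group on the same chain carbon: no change at the digits printed from compound 1 to compound 2 (within the scatter) and no change at the digits printed from compound 1 to compound 3 (within the scatter). Neither moved the read-out, so a further rearrangement of that aryl group is expected to leave it where it is, with no change at the digits printed from compound 3 to compound 4 (within the scatter). Compound 4 is therefore estimated at 3330 nM, with a range from 1500 nM to 7500 nM.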

Compound 4, concentration for 50% growth inhibition: 3330 nM
Beside the measured number, compound 4's estimate shows no gap at the digits printed; measured number inside the range.
By their numbers in this assay, from the lowest: compounds 1, 2, 3 and 4 (each within the scatter of the next).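

In this assay, going by these compounds alone, the change from 2-methylphenyl to 4-methylphenyl on this chain carbon shows no change at the digits printed from compound 3 to compound 4 (within the scatter) and is the first step here that keeps the same methyl and alters only where it sits on the aryl group. Methyl in place of ethoxy shows no change at the digits printed from compound 2 to compound 4 (within the scatter) and methyl in place of chloro shows no change at the digits printed from compound 1 to compound 4 (within the scatter) so the four aryl groups shown read alike. No supporting measurement bears on this flat read-out.

The compounds shown leave open whether an amine or a carboxylic acid on the aryl group, or a longer chain to the amide-type nitrogen, would shift the read-out.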